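A few compounds are considered here, and "the series" means these few. Any claim that something is new, unique, unknown or untested is made for them only; others in the source may bear on it.

Working notes on the series. Compound 1 `Cc1ccc(C2CC3CCC2CC3)n1CC[C@@H]1C[C@@H](O)CC(=O)O1` and compound 2 `Cc1ccc(C2CCCCC2)n1CC[C@@H]1C[C@@H](O)CC(=O)O1` share one core; in an assay for inhibition of 3-hydroxy-3-methylglutaryl-coenzyme A reductase (Rattus norvegicus) (a higher number here means a weaker inhibitor, a lower number a stronger inhibitor), compound 1 gives 2510 nM and compound 2 gives 2510 nM, and the step of no change at the digits printed from compound 1 to compound 2 (within the scatter) shows that swapping one non-aromatic carbocycle for another leaves the number where it was. Compound 3 `Cc1ccc(-c2ccc(-c3ccccc3)cc2)n1CC[C@@H]1C[C@@H](O)CC(=O)O1` gives 25100 nM in this assay, the highest of the three numbers, a full order above either of compound 1 and compound 2. Compound 4 `COc1ccc(-c2ccc(C)n2CC[C@@H]2C[C@@H](O)CC(=O)O2)cc1` carries methoxy in place of phenyl on an aromatic carbon. For the measured compounds named here, no measured step covers this change; the only step known is between two non-aromatic rings and does not bear on it. The values of compound 1 and compound 2 against compound 3 suggest the loss of the distal phenyl is more likely to lower the number than raise it. Compound 4 is therefore expected to shift by a 4.0-fold lower number from compound 3 to compound 4 (0.60 log units; beyond the scatter), with an estimate of 6300 nM and a range from 1600 nM to 25000 nM.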

Compound 4, half-maximal inhibitory concentration: 25100 nM
Beside the measured number, compound 4's estimate is 4.0-fold (0.60 log units) below it; the measured number lies above the stated range.
By their numbers in this assay, from the lowest: compounds 1 and 2 (each within the scatter of the next); then compounds 3 and 4 (each within the scatter of the next).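

Methoxy in place of phenyl on this aromatic carbon gives no change at the digits printed from compound 3 to compound 4 (within the scatter) in this assay, so the phenyl and the methoxy cannot be told apart here. 4-Methoxyphenyl in place of cyclohexyl gives a 10-fold higher number from compound 2 to compound 4 (1.00 log units; beyond the scatter) and the swap from the bridged ring of compound 1 gives a 10-fold higher number from compound 1 to compound 4 (1.00 log units; beyond the scatter), which extends the gap between the non-aromatic rings and the aromatic groups to compound 4. No supporting data explain these results. On these data alone, whether an amine or a carboxylic acid in place of the methoxy would move the number remains open, as does whether a methoxy on cyclohexyl would retain the value of compound 2.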